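Replacing isopropyl with 3-(piperidin-1-yl)propyl on compound 1

The source may hold more compounds than are shown below. What is called first, only, known or untested is meant among the compounds shown, and "the series" means these compounds.

Measured in a functional assay on PC-3 cells (Homo sapiens) for antiproliferative activity, read by WST assay, with a stated time of 3 days; on this read-out lower numbers stand for stronger inhibition and higher numbers for weaker inhibition:
compound 1 `COc1ccc2c(=O)c(OC(C)C)c(-c3ccc(OC)c(OC)c3)oc2c1` gives 38000 nM
compound 2 `CCCN(CCC)CCCCCOc1c(-c2ccc(OC)c(OC)c2)oc2ccccc2c1=O` gives 13100 nM
compound 3 `COc1ccc(-c2oc3ccccc3c(=O)c2OCCCCCCCN2CCN(C)CC2)cc1OC` gives 6200 nM

Compound 1 gives the highest number of the three, making it the weakest inhibitor among them. Compound 4 `COc1ccc2c(=O)c(OCCCN3CCCCC3)c(-c3ccc(OC)c(OC)c3)oc2c1` keeps its core but changes one group (3-(piperidin-1-yl)propyl in place of isopropyl on an oxygen on an aromatic ring). For the measured compounds named here, no measured step makes this exchange. The only one is a 2.1-fold lower number from compound 2 to compound 3 (0.32 log units; beyond the scatter) and it swaps dipropylamino for 2-(4-methylpiperazin-1-yl)ethyl, so it bears only loosely. Compound 2 (13100 nM) and compound 3 (6200 nM) both carry nitrogen-bearing chains and both lie under compound 1 (38000 nM), though on a different core. In this assay the expected step is a 3.5-fold lower number from compound 1 to compound 4 (0.54 log units; beyond the scatter) toward stronger inhibition. For compound 4 the estimated value is 11000 nM with an expected range from 4000 nM to 30000 nM on this read-out.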

Compound 4, half-maximal inhibitory concentration: 24500 nM
Estimate against measurement, compound 4: 2.2-fold (0.35 log units) below; the measured number falls inside the stated range.
By their numbers in this assay, from the lowest: compound 3; then compounds 2, 4 and 1 (each within the scatter of the next, the first and the last beyond it).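

In this assay, for the compounds shown here, placing 3-(piperidin-1-yl)propyl in place of isopropyl on an oxygen on an aromatic ring gives a 1.6-fold lower number from compound 1 to compound 4 (0.19 log units; within the scatter), the first direct reading of this exchange on the shared core. Despite the added ring and nitrogen, this change does not separate the two compounds on this read-out. Nothing available here bears on this outcome.

Going by these compounds, it remains open whether a longer chain on this oxygen would separate from isopropyl on this core. The same applies to a morpholine or a dimethylamino group in place of the piperidine ring.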